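Adding a Methyl Group to the Anilide

The source may report more compounds than this note shows. Statements on the series, on what has been measured and on what is new or still open speak of the compounds shown alone.

This study follows three close relatives that share one core and differ only in the group attached to a carbonyl carbon. Compound 1 `CCOC(=O)c1c(O)c2cccnc2n(-c2ccccc2)c1=O` carries an ethoxy group there and in a functional assay on the whole organism for inhibition, with Rattus norvegicus as the target, read by cytopathic effect and paw edema, at a dose of 100 mg/kg by the oral route (a lower number here means less inhibition, a higher number more inhibition at the dose given (going by the name of the read-out)), compound 1 gives 15.5%. Compound 2 `O=C(Nc1ccccn1)c1c(O)c2cccnc2n(-c2ccccc2)c1=O` carries a (pyridin-2-yl)amino group in its place and in this assay compound 2 gives 14.6%; the step of a number 0.9 percentage points lower from compound 1 to compound 2 (within the scatter) lies within the scatter. Compound 3 `O=C(Nc1ccccc1)c1c(O)c2cccnc2n(-c2ccccc2)c1=O` carries an anilino group and in this assay compound 3 gives -15%, the lowest of the three numbers: the steps of a number 30.5 percentage points lower from compound 1 to compound 3 (beyond the scatter) and a number 29.6 percentage points lower from compound 2 to compound 3 (beyond the scatter) are both beyond the scatter, so compound 3 has the lowest number here.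

Compound 4 `Cc1cccc(NC(=O)c2c(O)c3cccnc3n(-c3ccccc3)c2=O)c1` is the next member. The change from compound 3 is methyl in place of hydrogen on an aromatic carbon, sitting on the anilino ring meta to the large group. Going by the values given here, no measured step shows what a methyl group on this ring does; the only related steps exchange the whole group on the amide nitrogen and both lie beyond the scatter. A single added methyl is a far smaller alteration, so a step of a number 7 percentage points higher from compound 3 to compound 4 (within the scatter) within the scatter is expected, and compound 4 is estimated at -8%, between -32% and 16%.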

Compound 4, a percentage reported as inhibition, in the whole organism at one dose (the size of the read-out at that dose, not a potency): 4.5%
The estimate for compound 4 lay 12.5 percentage points below the measured number, within the range that was stated.
By their numbers in this assay, from the lowest: compound 3; then compound 4; then compounds 2 and 1 (each within the scatter of the next).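

A single methyl on the anilino ring, one carbon on a group of the same shape, is enough to shift the number in this assay by a clear margin: the step is a number 19.5 percentage points higher from compound 3 to compound 4 (beyond the scatter) and it takes the series from a negative number to a positive one, so this spot, meta to the large group, is not a silent one. The methyl does not close the whole gap, though: the step of a number 10.1 percentage points lower from compound 2 to compound 4 (beyond the scatter) and the step of a number 11 percentage points lower from compound 1 to compound 4 (beyond the scatter) leave the (3-methylphenyl)amino compound still under the (pyridin-2-yl)amino and ethoxy compounds. Nothing available here bears on why the added methyl moves the number.

One substituent at one ring position cannot show whether this step belongs to the methyl group itself or to any group placed there; a chlorine atom, a methoxy group or an amino group on the same ring carbon would speak to that. On these data alone, it also remains open whether a methyl group on another carbon of the anilino ring, or an ethyl chain at this one, would move the number as far.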